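The source may hold more compounds than are shown below. What is called first, only, known or untested is meant among the compounds shown, and "the series" means these compounds.

Working notes on the series. Within the data shown here, in a functional assay on the whole organism (strain Swiss) with Mus musculus as the target, in the maximal electroshock model, with a stated time of 1 h, at a dose of 300 mg/kg by the intraperitoneal route (a lower number here means a weaker effect, a higher number a stronger effect of the compound at the dose given), compound 1 `COCC(C(=O)N1CCN(c2cccc(C(F)(F)F)c2)CC1)N1C(=O)CCC1=O` gives 100%, the highest of the three numbers measured so far. Its nearest neighbour in the numbers is compound 3 `CCC(C(=O)N1CCN(c2ccccc2F)CC1)N1C(=O)CCC1=O`, which in this assay gives 50%, a gap beyond the usual scatter; furthest away is compound 2 `CCC(C(=O)N1CCN(c2ccc(C(F)(F)F)cc2)CC1)N1C(=O)CCC1=O`, which in this assay gives 0%, also a gap beyond the scatter. Among the measured compounds shown here, no pair of these three differs in one place only, so no single step is isolated among the measured compounds.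

Compound 4 `CCC(C(=O)N1CCN(c2cccc(C(F)(F)F)c2)CC1)N1C(=O)CCC1=O` has not been measured. It differs from compound 1 in one place, (methyl in place of methoxy on a saturated chain carbon, two bonds along the chain from an amide-type nitrogen in a ring and a carbonyl carbon). For the measured compounds named here, the two measured compounds that carry the ethyl chain, compound 2 and compound 3, both sit well under compound 1, though each also differs from it elsewhere, so no clean step is known for this change. A downward step in this assay beyond the scatter is expected for compound 4, with a number 50 percentage points lower from compound 1 to compound 4 (beyond the scatter) as the expected size. For compound 4 the estimated value in this assay is 50%, with a range from 10% to 100%.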

Compound 4, a percentage reported as activity, at one dose (the size of the read-out at that dose, not a potency): 100%
For compound 4 the middle estimate is 50 percentage points below the measured one; measured number inside the range.
By their numbers in this assay, from the lowest: compound 2; then compound 3; then compounds 1 and 4 (each within the scatter of the next).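

At the saturated chain carbon, two bonds along the chain from an amide-type nitrogen in a ring and a carbonyl carbon, methyl in place of methoxy gives, in this assay, no change at the digits printed from compound 1 to compound 4 (within the scatter). With the trifluoromethyl-bearing remainder of compound 1 held fixed, the methoxy group is therefore not needed for the effect at this dose, and the ethyl chain by itself does not go with a low number. No measurement on hand explains this outcome.

The read-out is taken at a single dose, so a stronger or weaker effect of one of the two compounds at any other dose would not show in it. On these data alone, whether a longer chain such as propyl, or a primary amine or carboxylic acid, is tolerated at this carbon remains open.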